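Methoxy for Fluoro on a Weak REV1 Binder

This account rests on a few compounds, and the source may have more. Where it says the series, first, only, none or still open, it means among the compounds named here.

Measured compounds:
compound 1 `CCc1ccc(NC(=O)CN2CCN(c3ccc(F)cc3)CC2)cc1`: 6900 nM
compound 2 `N#Cc1ccc(NC(=O)CN2CCN(c3ccc(F)cc3)CC2)cc1`: "not determined" (no result reported)

Going by the values given here, compound 1 is the only compound with a number. In an assay for displacement of a labelled ligand from DNA repair protein REV1 (Homo sapiens), read by fluorescence polarization, with a stated time of 1 h (on this read-out lower numbers stand for stronger inhibition and higher numbers for weaker inhibition), compound 1 gives 6900 nM, which is a weak result. In this assay compound 2 gives "not determined" (no result reported), so nothing can be said about how it compares. Compound 3 `CCc1ccc(NC(=O)CN2CCN(c3ccc(OC)cc3)CC2)cc1` has not yet been measured. It differs from compound 1 in one place: methoxy in place of fluoro on an aromatic carbon, para to a large group. Among the compounds with values here, no pair of measured compounds shows a step of this kind, so there is no measured number to lean on. Within the data shown here, only the single value of compound 1 is available, and the expected change a 1.0-fold higher number from compound 1 to compound 3 (0.01 log units; within the scatter) is within the usual scatter, with no direction favoured. Compound 3 is estimated at 7000 nM in this assay, with a range from 2500 nM to 20000 nM.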

Compound 3, inhibition constant: 3600 nM
Compound 3: the middle estimate sits 1.9-fold (0.29 log units) above what was measured; the range from low to high includes it.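

In this assay, going by these compounds alone, putting methoxy in place of fluoro on this aromatic carbon gives a 1.9-fold lower number from compound 1 to compound 3 (0.28 log units; within the scatter), the first measured step at this position, and it leaves the two compounds indistinguishable. The position therefore accommodates methoxy, which brings 2 heavy atoms and 1 hydrogen-bond acceptor where fluoro had 1 heavy atom and no acceptor, with no difference that this measurement can resolve. No other data here offer an explanation for this result.

On these data alone, it remains open whether an amine, a carboxylic acid or a longer chain such as butoxy at this position would move the number beyond the scatter. As far as these compounds go, it is also open whether the swap from fluoro to methoxy would give the same result if another part of the shared core were changed.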